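A few compounds are considered here, and "the series" means these few. Any claim that something is new, unique, unknown or untested is made for them only; others in the source may bear on it.

Measured in a functional assay on HeLa cells (Homo sapiens) for cytotoxicity, read by MTT assay, with a stated time of 72 h; on this read-out lower numbers stand for stronger inhibition and higher numbers for weaker inhibition:
- compound 1 `CC(C)(C)C1=CC(=O)C=C(NCCC(=O)O)C1=O`: 47100 nM
- compound 2 `CC1=CCC[C@H]2[C@](C)(CC3=CC(=O)C(N4CCC[C@H]4C(=O)O)=CC3=O)[C@@H](C)CC[C@]12C`: 36200 nM
- compound 3 `CC1=CCC[C@H]2[C@](C)(CC3=CC(=O)C=C(NCCC(=O)O)C3=O)[C@@H](C)CC[C@]12C`: 8870 nM

Compound 1, at 47100 nM, holds the highest of the three numbers. Its gap to compound 2 at 36200 nM lies within the scatter, while compound 3 at 8870 nM sits lower by more than the scatter.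

Compound 4 `CC(C)(C)C1=CC(=O)C=CC1=O` departs from compound 1 with hydrogen in place of (2-carboxyethyl)amino on a double-bonded ring carbon, two ring bonds from the ring atom that bears a tert-butyl group (hydrogen in place of (2-carboxyethyl)amino on a double-bonded ring carbon). Within the data shown here, no measured pair isolates this change, and no measured compound lacks a nitrogen-linked acid chain, so the expectation carries real uncertainty. A moderate step towards a lower number is expected in this assay, although a step within the scatter cannot be ruled out. The expected change is a 3.1-fold lower number from compound 1 to compound 4 (0.50 log units; beyond the scatter). For compound 4 the estimated value is 15000 nM, with an expected range of 4000 nM to 45000 nM.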

Compound 4, half-maximal inhibitory concentration: 44100 nM
Compound 4: middle estimate off by 2.9-fold (0.47 log units), on the low side, within the range that was stated.
By their numbers in this assay, from the lowest: compound 3; then compounds 2, 4 and 1 (each within the scatter of the next).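

In this assay, hydrogen in place of (2-carboxyethyl)amino on a double-bonded ring carbon, two ring bonds from the ring atom that bears a tert-butyl group, gives a 1.1-fold lower number from compound 1 to compound 4 (0.03 log units; within the scatter), a step within the scatter. This is the first compound shown without a nitrogen-linked acid chain, and on the core of compound 1 the number does not depend on that chain at this position. Nothing available explains why the exchange leaves the number where it is.

As far as these compounds go, whether the same exchange would be as silent on the core of compound 3 remains open. So does whether a simple amine without the carboxylic acid, or a longer chain ending in a carboxylic acid, would read any differently at this position.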